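Cyclobutyl to Isopropyl on the Piperidine Substituent

The source may report more compounds than this note shows. Statements on the series, on what has been measured and on what is new or still open speak of the compounds shown alone.

Measured compounds:
compound 1, `COc1cccc(-n2cc3nc(-c4cccnc4C)n(C[C@H]4CCCN(CC5CCC5)C4)c(=O)c3n2)c1`, 1.6 nM in an assay on HEK293 cells for displacement of a labelled ligand from growth hormone secretagogue receptor type 1 (Homo sapiens), with a stated time of 60 min; on this read-out higher numbers stand for weaker inhibition and lower numbers for stronger inhibition
compound 2, `Cc1ccccc1-c1nc2cn(-c3ccc(Cl)cc3)nc2c(=O)n1CC1CCCN(C(C)C)C1`, 0.28 nM in this assay

Of the compounds shown here, two have been measured so far. Compound 1 gives 1.6 nM in this assay, which is the higher of the two numbers. Compound 2 differs from compound 1 in several places at once. In this assay, for the measured compounds named here, compound 2 gives 0.28 nM, a lower number that lies beyond the usual scatter; no single step links the two, so their values are simply set side by side.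

Compound 3, `COc1cccc(-n2cc3nc(-c4cccnc4C)n(C[C@H]4CCCN(CC(C)C)C4)c(=O)c3n2)c1`, has not yet been measured. It is compound 1 with isopropyl in place of cyclobutyl on a saturated chain carbon bound to an amine nitrogen in a ring. The cyclobutylmethyl group on the amine nitrogen becomes an isobutyl group.

Going by the values given here, nothing measured so far isolates this change, so the expectation rests on the small size of the difference. Compound 3 is expected to give 2 nM, with a range from 0.7 nM to 6 nM. The expected step of a 1.3-fold higher number from compound 1 to compound 3 (0.10 log units; within the scatter) is estimated to lie within the scatter of repeated measurements, in no firm direction.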

Compound 3, half-maximal inhibitory concentration: 5.7 nM
For compound 3 the middle estimate is 2.9-fold (0.45 log units) below the measured one, and the stated range covers the measured number.
By their numbers in this assay, from the lowest: compound 2; then compound 1; then compound 3.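

For the compounds shown here, compound 3 supplies the first comparison that differs in one place only, and in this assay it shows a 3.6-fold higher number from compound 1 to compound 3 (0.55 log units; beyond the scatter) on exchanging cyclobutyl for isopropyl on a saturated chain carbon bound to an amine nitrogen in a ring. This position therefore responds to the choice of group, even though neither group carries a hydrogen-bond donor, a hydrogen-bond acceptor or a net charge, and the step is read here on a single pair with the rest of the molecule held as in compound 1. No measurement at hand explains why the number rises with this exchange.

The compounds shown leave open whether the ring of cyclobutyl is what matters or simply the size of the group, a question that cyclopropyl, cyclopentyl or an open longer chain such as n-butyl in the same place would bear on. Going by these compounds alone, they also leave open whether the same step would appear with other aryl groups on the shared core, since only this one pair isolates the change.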